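This account rests on a few compounds, and the source may have more. Where it says the series, first, only, none or still open, it means among the compounds named here.

Compound 3 `CC(C)(C)N1C[C@@H](C(=O)Nc2nccn2Cc2ccccc2-c2ccccc2)[C@H](c2ccc(F)cc2F)C1` stands second highest of the three numbers in a functional assay for agonist activity at Melanocyte-stimulating hormone receptor (Homo sapiens), read by cAMP accumulation (a higher number here means that more compound is needed for the effect, a lower number that less compound is needed), giving 527 nM. Its nearest neighbour is compound 1 `Cc1ccc(Cn2ccnc2NC(=O)[C@@H]2CN(C(C)(C)C)C[C@H]2c2ccc(F)cc2F)c(N2CCC(C(=O)O)CC2)c1`, which gives 318 nM, within the scatter. The furthest is compound 2 `CC(C)(C)N1C[C@@H](C(=O)Nc2nccn2Cc2ccccc2)[C@H](c2ccc(F)cc2F)C1`, which gives 4660 nM. That gap is an 8.8-fold lower number from compound 2 to compound 3 (0.95 log units; beyond the scatter). Compound 4 `CC(C)(C)N1C[C@@H](C(=O)Nc2nccn2Cc2ccccc2N2CCC(C(=O)O)CC2)[C@H](c2ccc(F)cc2F)C1` carries 4-carboxypiperidin-1-yl in place of phenyl on an aromatic carbon. Among the compounds with values here, no measured step covers this exact exchange; the only measured step concerns the same aromatic carbon, an 8.8-fold lower number from compound 2 to compound 3 (0.95 log units; beyond the scatter), and compound 1 already holds the entering 4-carboxypiperidin-1-yl group while sitting within the scatter of compound 3. The expected step is therefore a 1.5-fold lower number from compound 3 to compound 4 (0.18 log units; within the scatter) in this assay, not beyond the scatter. Compound 4 is estimated at 350 nM, in a range from 120 nM to 1000 nM.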

Compound 4, half-maximal effective concentration: 460 nM
Compound 4: middle estimate off by 1.3-fold (0.12 log units), on the low side; low and high end bracket the measured number.
By their numbers in this assay, from the lowest: compounds 1, 4 and 3 (each within the scatter of the next); then compound 2.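

In this assay there is a 1.1-fold lower number from compound 3 to compound 4 (0.06 log units; within the scatter) when 4-carboxypiperidin-1-yl replaces phenyl on this aromatic carbon, and a 10-fold lower number from compound 2 to compound 4 (1.01 log units; beyond the scatter) when it replaces hydrogen, so a non-aromatic ring carrying a carboxylic acid serves here as well as the aromatic ring of phenyl. Hydrogen in place of methyl gives a 1.4-fold higher number from compound 1 to compound 4 (0.16 log units; within the scatter) and makes no readable difference. Nothing available explains these steps. The compounds shown leave open how a plain piperidine ring or a simple amine on this carbon would compare, and so whether the carboxylic acid matters.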